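Notes on the series: from compound 2 toward compound 4

This account rests on a few compounds, and the source may have more. Where it says the series, first, only, none or still open, it means among the compounds named here.

Of the compounds shown here, three share a common core and have been measured in a functional assay on T47D cells (Homo sapiens) for inhibition, read by sulforhodamine B assay, with a stated time of 48 h, tested at 10 uM; on this read-out lower numbers stand for a stronger effect and higher numbers for a weaker effect at the one concentration tested. Compound 1 `COc1cc(Cl)cc(-c2nn(-c3cccc(NC(=O)Nc4cccc(C(F)(F)F)c4)c3)cc2-c2ccncc2)c1` gives -0.45% in this assay. Compound 2 `COc1cc(Cl)cc(-c2nn(-c3cccc(NC(=O)Nc4ccc(Cl)c(C(F)(F)F)c4)c3)cc2-c2ccncc2)c1` gives 8.1%; compound 3 `COc1cc(Cl)cc(-c2nn(-c3cccc(NC(=O)c4cc(C(F)(F)F)cc(C(F)(F)F)c4)c3)cc2-c2ccncc2)c1` gives 53.4%. Among these three numbers compound 2 stands second highest: its nearest neighbour is compound 1, and the one measured single-place step, a number 8.6 percentage points higher from compound 1 to compound 2 (within the scatter), lies within the scatter. Compound 3 stands far above compound 2, but the two differ in more than one place, so no single step can be read from that pair.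

The next compound, compound 4 `COc1cc(Cl)cc(-c2nn(-c3cccc(NC(=O)c4ccc(Cl)c(Cl)c4)c3)cc2-c2ccncc2)c1`, differs from compound 2 in one place: 3,4-dichlorophenyl in place of (4-chloro-3-(trifluoromethyl)phenyl)amino on a carbonyl carbon. Within the data shown here, no measured step bears directly on this change. Among the measured compounds shown here, the only guidance is that compound 3 carries a different group at the same carbonyl carbon and gives 53.4%, well above compound 2, whereas the one measured step, a number 8.6 percentage points higher from compound 1 to compound 2 (within the scatter), concerns only a chloro substituent and is within the scatter.

An upward step of a number 26.9 percentage points higher from compound 2 to compound 4 (beyond the scatter) is therefore expected in this assay, with wide uncertainty. Compound 4 is estimated at 35%, with a range from 8% to 62%.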

Compound 4, a percentage reported as activity, at one concentration (the size of the read-out at that concentration, not a potency): 63.2%
Estimate against measurement, compound 4: 28.2 percentage points below, outside the stated range (above it).
By their numbers in this assay, from the lowest: compounds 1 and 2 (each within the scatter of the next); then compounds 3 and 4 (each within the scatter of the next).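

Both steps run the same way and are large: in this assay the change on the carbonyl carbon gives a number 55.1 percentage points higher from compound 2 to compound 4 (beyond the scatter) and a number 63.7 percentage points higher from compound 1 to compound 4 (beyond the scatter), so at the one concentration tested the effect is much weaker once the aryl group sits directly on that carbon. This position is therefore far more sensitive to the exchange of the whole group than the chloro step between compound 1 and compound 2, which stayed within the scatter, had suggested. Nothing available explains the size of these steps.

Each exchange removes the amino nitrogen, with its hydrogen-bond donor, and alters the ring substituents at once, so the compounds shown cannot separate the contribution of the nitrogen from that of the trifluoromethyl-to-chloro change. Also open, as far as these compounds go, is how the read-out responds to other groups on the same carbonyl carbon, such as a benzyl group, a cyclohexyl ring or a morpholine, and whether any of them keeps the stronger effect seen with compound 1 and compound 2.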